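This account rests on a few compounds, and the source may have more. Where it says the series, first, only, none or still open, it means among the compounds named here.

Going by the values given here, compound 3 `Clc1cccc(-c2cnc(Nc3ccccc3)nc2-c2ccccc2)c1` gives 34% in an assay on CHO cells for displacement of a labelled ligand from adenosine receptor A1 (Homo sapiens), read by scintillation counting, with a stated time of 1 h, tested at 1 uM (on this read-out higher numbers stand for more inhibition at the one concentration tested (going by the name of the read-out) and lower numbers for less inhibition), and this is the only plain number among the three measured compounds. Compound 1 `Nc1ncc(-c2cccc(Cl)c2)c(-c2ccccc2)n1` sits at a limit of this assay, > 80%, rather than at a number. Compound 2 `CCCC(=O)Nc1ncc(-c2cccc(Cl)c2)c(-c2ccccc2)n1` also sits at a limit, > 80%. Two of the three values thus stand at the limit of > 80% in this assay, at which 2 of the 3 values shown sit. The measured steps are a number at least 46 percentage points lower from compound 1 to compound 3 (beyond the scatter) and a number at least 46 percentage points lower from compound 2 to compound 3 (beyond the scatter), while a step that the two limits leave unreadable from compound 1 to compound 2. Compound 4 `CCCCNc1ncc(-c2cccc(Cl)c2)c(-c2ccccc2)n1` differs from compound 3 by butyl in place of phenyl on a nitrogen on an aromatic ring. Hydrogen and propylcarbonyl on that nitrogen both reach the limit, and phenyl alone falls far below it. Butyl is expected to recover most of that loss, so the expected step is a number 41 percentage points higher from compound 3 to compound 4 (beyond the scatter). Compound 4 is therefore estimated at 75%, within a range from 45% to 95%.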

Compound 4, a percentage reported as inhibition, at one concentration (the size of the read-out at that concentration, not a potency): 56%
The estimate for compound 4 lay 19 percentage points above the measured number; the measured number falls inside the stated range.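

Butyl in place of phenyl on this nitrogen gives a number 22 percentage points higher from compound 3 to compound 4 (beyond the scatter), so a plain carbon chain retains more inhibition here than the phenyl ring does. Yet butyl in place of hydrogen gives a number at least 24 percentage points lower from compound 1 to compound 4 (beyond the scatter), and butyl in place of propylcarbonyl gives a number at least 24 percentage points lower from compound 2 to compound 4 (beyond the scatter). Both of these steps start from a limit of the assay, not from a number: the limit of > 80% in this assay, at which 2 of the 4 values shown sit.

From the compounds shown here alone, how a shorter chain, a longer chain or a chain ending in an amine would read on this nitrogen stays open. Readings at a single concentration also leave the potency of these compounds open.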